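Halogen for methoxy on the benzylamine of compound 2

The compounds below may be only part of what the source reports. "The series", "measured", "known", "first", "only" and "open" are said of these compounds alone.

Within the data shown here, compound 2 `COc1cccc(CNCCCNS(=O)(=O)c2cc(C(F)(F)F)cc(C(F)(F)F)c2)c1` gives the highest of the two numbers so far in a functional assay on PANC-1 cells (Homo sapiens) for inhibition, read by MTT assay, with a stated time of 72 h (a lower number here means a stronger inhibitor of growth, a higher number a weaker inhibitor of growth), at 10000 nM; the nearest is compound 1 `O=S(=O)(NCCCCNCc1ccc(Br)cc1)c1cc(C(F)(F)F)cc(C(F)(F)F)c1`, which in this assay gives 2200 nM. Compound 3 `O=S(=O)(NCCCNCc1ccc(Cl)cc1)c1cc(C(F)(F)F)cc(C(F)(F)F)c1` differs from compound 2 by 4-chlorophenyl in place of 3-methoxyphenyl on a saturated chain carbon bound to an amine nitrogen. Among the measured compounds shown here, the only measured step that bears on this is a 4.5-fold higher number from compound 1 to compound 2 (0.66 log units; beyond the scatter), where the aryl substituent changed together with the chain length, so it speaks only in part. Compound 3 is expected to move part of the way back, by a 2.5-fold lower number from compound 2 to compound 3 (0.40 log units; beyond the scatter). For compound 3 the estimate in this assay is 4000 nM, within 1500 nM to 12000 nM.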

Compound 3, concentration for 50% growth inhibition: 4900 nM
For compound 3 the middle estimate is 1.2-fold (0.09 log units) below the measured one; low and high end bracket the measured number.
By their numbers in this assay, from the lowest: compound 1; then compound 3; then compound 2.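

In this assay, among these compounds, the aryl group alone changes for the first time: a 2.0-fold lower number from compound 2 to compound 3 (0.31 log units; beyond the scatter) with 4-chlorophenyl in place of 3-methoxyphenyl on a saturated chain carbon bound to an amine nitrogen, though substituent and ring position change together. Compound 1 keeps the lowest number, and a 2.2-fold higher number from compound 1 to compound 3 (0.35 log units; beyond the scatter) with halogen and chain changing at once, so neither can be credited alone. Nothing measured here accounts for either step.

Open, as far as these compounds go, is how the gap to compound 1 divides between bromine and chain, and how a nitrile on the aryl ring or a longer chain would read.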